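Methyl in Place of Methoxy: Expectation for Compound 3

A few compounds are considered here, and "the series" means these few. Any claim that something is new, unique, unknown or untested is made for them only; others in the source may bear on it.

Measured compounds:
compound 1, `COC(=O)c1c(Nc2ccccc2)sc(C(=O)c2ccc(OC)cc2)c1C`: 28.6%
compound 2, `COC(=O)c1c(Nc2ccc(OC)cc2)sc(C(=O)c2ccc(OC)cc2)c1C`: 7.8%

Of the compounds shown here, two have been measured in a functional assay, with a stated time of 150 min, tested at 15 ug/mL; on this read-out higher numbers stand for a stronger effect at the one concentration tested and lower numbers for a weaker effect. Compound 1 gives 28.6%, the higher of the two numbers, and compound 2 gives 7.8%. Going by the values given here, the only step between them, a number 20.8 percentage points lower from compound 1 to compound 2 (beyond the scatter), comes from the difference methoxy in place of hydrogen on an aromatic carbon.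

Compound 3, `COC(=O)c1c(Nc2ccccc2)sc(C(=O)c2ccc(C)cc2)c1C`, has not been measured. It differs from compound 1 in another place: methyl in place of methoxy on an aromatic carbon. Among the compounds with values here, no measured step covers a change at this place, so the step from compound 1 to compound 2 bears on it only as a reminder that exchanging a single group can move the number beyond the scatter. With nothing more to go on, a small step is expected, a number 3.6 percentage points lower from compound 1 to compound 3 (within the scatter), with a range wide enough to allow a fall. Compound 3 is therefore estimated to give 25%, between 8% and 45%.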

Compound 3, a percentage reported as activity, at one concentration (the size of the read-out at that concentration, not a potency): 4.59%
The estimate for compound 3 lay 20.4 percentage points above the measured number; the measured number lies below the stated range.
By their numbers in this assay, from the lowest: compounds 3 and 2 (each within the scatter of the next); then compound 1.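

In this assay, going by these compounds alone, the change from 4-methoxyphenyl to 4-methylphenyl gives a number 24 percentage points lower from compound 1 to compound 3 (beyond the scatter), so this position, which no earlier step touched, does not tolerate every small exchange. The change is small on paper: methyl replaces methoxy, and one oxygen and one hydrogen-bond acceptor leave with it. No measurement shown here explains the fall.

The compounds shown carry only methoxy and methyl at this position, so it stays open whether a hydrogen, a chlorine, an amine or a carboxylic acid there would match or exceed compound 1. Also open, on these data alone, is whether the other change, seen as a number 20.8 percentage points lower from compound 1 to compound 2 (beyond the scatter), would have the same size on a core carrying the 4-methylphenyl group.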